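The source may report more compounds than this note shows. Statements on the series, on what has been measured and on what is new or still open speak of the compounds shown alone.

Compound 1 `c1ccc(-c2cccc3c2CCC3c2ncc[nH]2)nc1` stands lowest of the two numbers recorded in a functional assay on CHO cells for agonist activity at Alpha-1A adrenergic receptor (Homo sapiens), read by FLIPR and calcium flux (a higher number here means a larger maximal response, a lower number a smaller maximal response), where compound 1 gives 53%. Its nearest neighbour is compound 2 `Cc1c(OCC2=NCCN2)ccc(Cl)c1NS(C)(=O)=O`, a sulfonamide-bearing compound with a different core, which in this assay gives 60%; the two values lie within the scatter of each other, so the data say nothing about an order between them. Compound 3 `Cn1nccc1-c1cccc2c1CCC2c1ncc[nH]1` keeps the core of compound 1 and differs from it only in one aromatic group: 1-methyl-1H-pyrazol-5-yl in place of pyridin-2-yl on an aromatic carbon. Among the measured compounds shown here, no pair of measured compounds shows the effect of such a change, so there is no measured step to lean on, and the account expects a step that is no larger than the scatter, with no preferred direction. The expected step of a number 1 percentage points lower from compound 1 to compound 3 (within the scatter) is accordingly small. Compound 3 is therefore estimated at 52%, with a likely range from 30% to 75%.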

Compound 3, largest response reached (Emax), in percent of the reference or control that the assay uses: 58%
Beside the measured number, compound 3's estimate is 6 percentage points below it, and the stated range covers the measured number.
By their numbers in this assay, from the lowest: compounds 1, 3 and 2 (each within the scatter of the next).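

In this assay, among the compounds shown here, the change from pyridin-2-yl to 1-methyl-1H-pyrazol-5-yl gives the first measured step at this place on the core, a number 5 percentage points higher from compound 1 to compound 3 (within the scatter). The result shows that, on this aromatic carbon, a five-membered aromatic ring with 2 hetero atoms can stand in for a six-membered aromatic ring with 1 hetero atom, with no difference in maximal response that can be told from the scatter. Nothing available explains why the response holds across this change.

The compounds shown contain only these two aromatic groups at this place, so they leave open whether the response would hold with a carboxylic acid, an amine or a longer alkyl chain there. A single step also cannot show how far this result extends to other aromatic rings, such as phenyl or pyridin-3-yl.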